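The compounds below may be only part of what the source reports. "The series", "measured", "known", "first", "only" and "open" are said of these compounds alone.

Within the data shown here, compound 2 `CN(C)S(=O)(=O)c1ccc(NC(=O)C(C)(O)C(F)(F)F)cc1` gives 480 nM in an assay on a protein complex (Cavia porcellus) with sulfonylurea receptors; K-ATP channels (Homo sapiens) as the target (on this read-out higher numbers stand for weaker inhibition and lower numbers for stronger inhibition), and is the only number among the two values shown. Compound 1 `CC(O)(C(=O)Nc1ccc([C@H](O)c2ccccc2)cc1)C(F)(F)F` returns only a limit in this assay, > 30000 nM. The step of an at least 62-fold lower number from compound 1 to compound 2 (1.79 log units; beyond the scatter) is read against the limit of > 30000 nM in this assay, at which 1 of the 2 values shown sits, and bears on a different position. Compound 3 `CC(O)(C(=O)Nc1ccc(S(=O)(=O)N2CCCC2)cc1)C(F)(F)F` differs from compound 2 in one place: pyrrolidin-1-yl in place of dimethylamino on a sulfonyl sulfur. Among the measured compounds shown here, no measured step covers a change of this kind on the sulfonyl sulfur. The expectation for compound 3 is therefore a step of a 1.2-fold lower number from compound 2 to compound 3 (0.08 log units; within the scatter) that stays within the scatter. Compound 3 is estimated at 400 nM, between 150 nM and 1500 nM.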

Compound 3, half-maximal inhibitory concentration: 880 nM
Estimate against measurement, compound 3: 2.2-fold (0.34 log units) below; the measured number falls inside the stated range.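

Pyrrolidin-1-yl in place of dimethylamino on a sulfonyl sulfur gives a 1.8-fold higher number from compound 2 to compound 3 (0.26 log units; within the scatter), so compound 2 and compound 3 cannot be told apart here, even with the added ring. The large gap to the hydroxy(phenyl)methyl compound also holds with this second sulfonyl group, as an at least 34-fold lower number from compound 1 to compound 3 (1.53 log units; beyond the scatter). The size of that step is only a bound, set by a limit: the limit of > 30000 nM in this assay, at which 1 of the 3 values shown sits.

Open, as far as these compounds go, is whether a morpholine or piperidine ring, or an unsubstituted amine, on the sulfonyl sulfur would stay within the same range. Also open, from the compounds shown here alone, is whether a sulfonyl group is needed at all, or whether a carboxylic acid or a nitrile on the aromatic carbon would serve equally.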